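Compound 1 and a chlorinated urea analogue

This account rests on a few compounds, and the source may have more. Where it says the series, first, only, none or still open, it means among the compounds named here.

- compound 1 (`Cc1ccc(C)c(NC(=O)Nc2nc(Sc3c[nH]c4ccccc34)cc(N3CCCCC3)n2)c1`): (5940 nM)
- compound 2 (`O=C(Nc1ccccc1)Nc1nc(Sc2c[nH]c3ccccc23)cc(N2CCCC2)n1`): (7890 nM)

In a functional assay on MDA-MB-231 cells (Homo sapiens) for inhibition, with a stated time of 72 h (on this read-out lower numbers stand for stronger inhibition and higher numbers for weaker inhibition), the numbers for compound 1 and compound 2 lie within the usual scatter of each other, so neither can be ranked above the other. Compound 3 (`O=C(Nc1ccc(Cl)cc1)Nc1nc(Sc2c[nH]c3ccccc23)cc(N2CCCCC2)n1`) has not yet been measured. It carries 4-chlorophenyl in place of 2,5-dimethylphenyl on an amide-type nitrogen. Among the compounds with values here, no measured pair shows this change alone, so the expected step (a 1.2-fold lower number from compound 1 to compound 3 (0.07 log units; within the scatter)) stays within the scatter, with no firm direction. For compound 3 the estimated value is (5000 nM), within an expected range from (1800 nM) to (13000 nM).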

Compound 3, half-maximal inhibitory concentration: 10100 nM
Estimate against measurement, compound 3: 2.0-fold (0.31 log units) below; the range from low to high includes it.
By their numbers in this assay, from the lowest: compounds 1, 2 and 3 (each within the scatter of the next).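

In this assay, replacing 2,5-dimethylphenyl with 4-chlorophenyl on the amide-type nitrogen gives a small step (a 1.7-fold higher number from compound 1 to compound 3 (0.23 log units; within the scatter)). So at this position, two differently substituted phenyl groups cannot be told apart, and this change has no firm direction. No other measurement available here bears on this result. On these data alone, it remains open whether a group of another kind on that nitrogen, such as a phenyl ring carrying an amine or a carboxylic acid, would move the number beyond the scatter.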